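Adding a Third Methoxy Group on the Aryl Amine

A few compounds are considered here, and "the series" means these few. Any claim that something is new, unique, unknown or untested is made for them only; others in the source may bear on it.

compound 1 `Cc1ccc(S(=O)(=O)/N=C(/CCNC2=CC(=O)c3ccccc3C2=O)Nc2ccc(F)cc2)cc1`: 12200 nM
compound 2 `COc1ccc(N/C(CCNC2=CC(=O)c3ccccc3C2=O)=N\S(=O)(=O)c2ccc(C)cc2)c(OC)c1`: 67300 nM

Both measured compounds share one core and differ only in the aryl group on the amine nitrogen. In a functional assay on DU-145 cells (Homo sapiens) for cytotoxicity, read by MTT assay, with a stated time of 48 h (on this read-out lower numbers stand for stronger inhibition and higher numbers for weaker inhibition), compound 2 gives the higher of the two numbers; its nearest neighbour is compound 1, and the change of a 5.5-fold higher number from compound 1 to compound 2 (0.74 log units; beyond the scatter) lies beyond the scatter. Compound 3 `COc1cc(N/C(CCNC2=CC(=O)c3ccccc3C2=O)=N\S(=O)(=O)c2ccc(C)cc2)cc(OC)c1OC` has not yet been measured in this assay. The change from compound 2 to compound 3 is 3,4,5-trimethoxyphenyl in place of 2,4-dimethoxyphenyl on an amine nitrogen. Within the data shown here, the single measured step bears on it only loosely: it shows that going from 4-fluorophenyl to a methoxy-bearing phenyl raised the number, whereas here one methoxy-bearing phenyl replaces another. Among the measured compounds shown here, with no direct precedent, a step of modest size or none beyond the scatter is expected, more likely upward than downward. Compound 3 is therefore estimated at 85000 nM in this assay, within a range of 30000 nM to 240000 nM, which means an expected step of a 1.3-fold higher number from compound 2 to compound 3 (0.10 log units; within the scatter).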

Compound 3, half-maximal inhibitory concentration: 9330 nM
Estimate against measurement, compound 3: 9.1-fold (0.96 log units) above; the whole stated range lies above it.
By their numbers in this assay, from the lowest: compounds 3 and 1 (each within the scatter of the next); then compound 2.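

In this assay, the change to 3,4,5-trimethoxyphenyl on the amine nitrogen gives a 7.2-fold lower number from compound 2 to compound 3 (0.86 log units; beyond the scatter), so the earlier rise on going to 2,4-dimethoxyphenyl cannot be read as a general penalty for methoxy groups on this aryl ring. The 3,4,5-trimethoxyphenyl and 4-fluorophenyl groups are not told apart here, with a 1.3-fold lower number from compound 1 to compound 3 (0.12 log units; within the scatter), which leaves compound 2 alone with the highest number of the three and shows that this position tolerates quite different aryl groups without a change beyond the scatter. Nothing in the data at hand explains why the two methoxy-bearing groups part so clearly.

The two methoxy-bearing groups differ both in how many methoxy groups they carry and in where these sit, so the compounds shown cannot say which of the two matters. From the compounds shown here alone, how a plain phenyl group, a phenyl group with a single methoxy group, or a benzyl group would stand at this nitrogen also remains open.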